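Aryl amide in place of acetyl on the chromenone series

The source may report more compounds than this note shows. Statements on the series, on what has been measured and on what is new or still open speak of the compounds shown alone.

Measured compounds:
compound 1 `CN(C)c1ccc(C(=O)Nc2cccc(NC(=O)COc3ccc4c(c3)NC(=O)CC4)c2)cc1` gives 3140 nM
compound 2 `COc1cccc(OCC(=O)Nc2cccc(NC(=O)c3ccc(N(C)C)cc3)c2)c1` gives 5740 nM
compound 3 `CC(=O)Nc1cccc(NC(=O)COc2ccc3c(=O)ccoc3c2)c1` gives 136 nM

In an assay on isolated protein for inhibition of Rho-associated protein kinase 2 (Homo sapiens), read by scintillation counting, radiometric assay and 33P incorporation, with a stated time of 40 min, in the presence of a further agent that is not named here (on this read-out higher numbers stand for weaker inhibition and lower numbers for stronger inhibition), compound 3 stands lowest of the three and is the most potent; compound 1 is the nearest, and compound 2 the furthest. Compound 4 `COC(=O)c1ccc(C(=O)Nc2cccc(NC(=O)COc3ccc4c(=O)ccoc4c3)c2)cc1` has not been measured. It differs from compound 3 in one place: 4-(methoxycarbonyl)phenyl in place of methyl on a carbonyl carbon. For the measured compounds named here, the only measured step, a 1.8-fold higher number from compound 1 to compound 2 (0.26 log units; within the scatter), concerns the ether end of the molecule and not the amide end, so it does not bear directly on this change. Compounds 1 and 2 carry an aryl amide at the same carbonyl and sit well above compound 3, but they differ from it at the ether end too, so their gap cannot be assigned to the amide. With no direct guide, the step is expected to be a moderate weakening, a 2.6-fold higher number from compound 3 to compound 4 (0.41 log units; beyond the scatter), with a wide margin. Compound 4 is therefore estimated at 350 nM, in the range 70 nM to 1800 nM.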

Compound 4, half-maximal inhibitory concentration: 29 nM
The estimate for compound 4 lay 12-fold (1.08 log units) above the measured number; measured number below the stated range.
By their numbers in this assay, from the lowest: compound 4; then compound 3; then compounds 1 and 2 (each within the scatter of the next).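

In this assay, putting 4-(methoxycarbonyl)phenyl in place of methyl on the carbonyl carbon gives a 4.7-fold lower number from compound 3 to compound 4 (0.67 log units; beyond the scatter), a step beyond the scatter and the only one shown at this place. It shows that the position, on a carbonyl carbon whose other neighbour is an amide-type nitrogen, is not restricted to a group as small as methyl: a much larger group carrying an aromatic ring goes with stronger inhibition. Nothing available explains this gain.

On these data alone, it remains open whether the gain belongs to the phenyl ring or to the methoxycarbonyl group on it, and what an unsubstituted phenyl, or a carboxylic acid or an amine in place of the methoxycarbonyl, would give here. As far as these compounds go, whether the gain would carry over to other groups at the ether end also remains open.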